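Benzamide series: piperazine to piperidine at the purine carbon

The compounds below may be only part of what the source reports. "The series", "measured", "known", "first", "only" and "open" are said of these compounds alone.

Measured compounds:
- compound 1 `CN1CCN(c2nc(Cl)nc3c2ncn3Cc2ccc(C(=O)Nc3ccccc3N)cc2)CC1`: 72.8%
- compound 2 `Cc1ccc(Nc2nc(Cl)nc3c2ncn3Cc2ccc(/C=C/C(=O)Nc3ccccc3N)cc2)cc1`: 15%
- compound 3 `Nc1ccccc1NC(=O)c1ccc(COCNc2nc(Nc3ccc(-c4ccccc4)cc3)c3ncn(C4CCCC4)c3n2)cc1`: 25.8%

In a functional assay on HCT-116 cells (Homo sapiens) for antiproliferative activity, read by CCK-8 assay, with a stated time of 72 h, tested at 8 uM (a higher number here means a stronger effect of the compound at the concentration tested, a lower number a weaker effect), compound 1 gives the highest of the three numbers shown. Compound 3 comes nearest, and its number lies beyond the scatter below compound 1; compound 2 lies furthest, also beyond the scatter. Compound 1 is thus the strongest of the three in this assay. Going by the values given here, no two of the measured compounds differ in one place only, so no single step is on hand for comparison.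

Compound 4 `CC1CCN(c2nc(Cl)nc3c2ncn3Cc2ccc(C(=O)Nc3ccccc3N)cc2)CC1` is the unmeasured compound. It differs from compound 1 in one place: 4-methylpiperidin-1-yl in place of 4-methylpiperazin-1-yl on an aromatic carbon. The change sits on an aromatic carbon of the six-membered aromatic ring with 2 nitrogen within the fused system of two rings, and the rest of the shared core, with the benzamide bearing the aminophenyl group, is kept. Among the compounds with values here, since no step is known for this kind of exchange, the estimate for compound 4 rests on compound 1 alone, with 72.8% as the anchor, and allows for a small loss. For compound 4 the expected value is 62%, within 40% to 80%, which as a step from compound 1 to compound 4 is estimated at a number 10.8 percentage points lower from compound 1 to compound 4 (beyond the scatter), a step that may or may not exceed the scatter.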

Compound 4, a percentage reported as inhibition, at one concentration (the size of the read-out at that concentration, not a potency): 78.6%
Compound 4: the middle estimate sits 16.6 percentage points below what was measured, and the stated range covers the measured number.
By their numbers in this assay, from the lowest: compound 2; then compound 3; then compounds 1 and 4 (each within the scatter of the next).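

In this assay the step with 4-methylpiperidin-1-yl in place of 4-methylpiperazin-1-yl on an aromatic carbon is a number 5.8 percentage points higher from compound 1 to compound 4 (within the scatter), so this pair shows no difference in the read-out at the concentration tested. At this position, next to the ring nitrogen, a ring with 1 hetero atom therefore reads the same as a ring with 2 hetero atoms, with the rest of the shared core kept, though this rests on one pair only. No measured evidence bears on why the two compounds read alike.

Open, on these data alone, is how groups such as morpholin-4-yl, pyrrolidin-1-yl or an open-chain dimethylamino group would read at this carbon. A read-out at a single concentration also leaves open whether the two compounds differ in potency.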